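Swapping Furan for Methylthiophene: What One Step Can Say

The compounds below may be only part of what the source reports. "The series", "measured", "known", "first", "only" and "open" are said of these compounds alone.

Compound 1 `Cc1cccc(-c2ccccc2OCC2=NCCN2)n1` reaches only the assay limit of < 100000 nM in a functional assay for activation of Alpha-1D adrenergic receptor (Homo sapiens), read by calcium flux; on this read-out higher numbers stand for an effect only at larger amounts of compound and lower numbers for an effect already at smaller amounts.
Compound 2 `c1coc(-c2ccccc2OCC2=NCCN2)c1` likewise reaches only the limit of < 100000 nM in this assay.
Compound 3 `c1ccc(-c2cc[nH]n2)c(OCC2=NCCN2)c1` also sits at the limit of < 100000 nM in this assay.

Compound 2 therefore stands nowhere definite on the numbers shown: its result is a limit, not a measured value, and the same is true of its two neighbours, as the limit of < 100000 nM in this assay, at which 3 of the 3 values shown sit, records. The one step that joins two of these compounds, a step that the two limits leave unreadable from compound 2 to compound 3, cannot be read, since both ends of it are limits.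

Compound 4 `Cc1ccc(-c2ccccc2OCC2=NCCN2)s1` is not yet measured. It differs from compound 2 by one change, (5-methylthiophen-2-yl in place of furan-2-yl on an aromatic carbon). Within the data shown here, the only measured step that touches this pair of rings, a step that the two limits leave unreadable from compound 2 to compound 3, gives no size and no direction, so nothing here predicts whether the change to 5-methylthiophen-2-yl moves the result at all.

On that footing, the expected outcome for compound 4 in this assay is most likely another limit rather than a number. Should a number appear, the estimate for compound 4 is 50000 nM, within 5000 nM to 100000 nM. That expectation corresponds to a step that the limit leaves unreadable from compound 2 to compound 4 from compound 2, which is no step beyond the scatter.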

Compound 4, half-maximal effective concentration: < 100000 nM
Compound 4 was reported as a limit (the forecaster's own chance of this, stated with the estimate: 70%); the middle value lies beyond the limit too.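

Compound 4 joins compound 2 and compound 3 as a limit rather than a number, so no new step can be read from compound 2 to compound 4 or from compound 3 to compound 4, and all results stop at the same place: the limit of < 100000 nM in this assay, at which 4 of the 4 values shown sit.

The compounds shown leave open whether exchanging these ring groups changes the result in this assay at all, and by how much.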